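Pyrrolidine-carboxamide series: amide variation on the shared core

The source may report more compounds than this note shows. Statements on the series, on what has been measured and on what is new or still open speak of the compounds shown alone.

Measured so far in an assay on the whole organism (plasma, strain Sprague-Dawley) for inhibition of Dipeptidyl peptidase 4 (Rattus norvegicus), with a stated time of 6 h, at a dose of 1 mg/kg by the oral route; a higher number here means more inhibition at the dose given (going by the name of the read-out), a lower number less inhibition:
compound 1 `N#C[C@@H]1CCCN1C(=O)[C@@H]1C[C@H](C(=O)N2CCOCC2)CN1` gives 73%
compound 2 `CCC[C@@H]1CN[C@H](C(=O)N2CCC[C@H]2C#N)C1` gives 50%
compound 3 `CN(C)C(=O)C[C@@H]1CN[C@H](C(=O)N2CCC[C@H]2C#N)C1` gives 66%

Compound 3 stands second of the three numbers. Its nearest neighbour is compound 1, whose number is higher but within the scatter, so no order between these two can be claimed. Among the compounds with values here, compound 2 stands clearly lower; the step of a number 16 percentage points higher from compound 2 to compound 3 (beyond the scatter) is beyond the scatter and is the only measured step in this set.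

Compound 4 `CCN(CC)C(=O)[C@@H]1CN[C@H](C(=O)N2CCC[C@H]2C#N)C1` differs from compound 3 in one place: diethylcarbamoyl in place of (dimethylcarbamoyl)methyl on a saturated ring carbon. The change keeps an amide but removes the chain carbon so that the carbonyl sits on the ring carbon itself, and the amide nitrogen carries two ethyl groups instead of two methyl groups. Within the data shown here, no measured step covers this shift of the amide onto the ring carbon. Compound 1 also carries an amide on a saturated ring carbon of the shared core and gives 73%, which is within the scatter of compound 3. The step from compound 2 to compound 3 shows that adding a carbamoyl-bearing group raised inhibition, and compound 4 retains such a group. The expectation is therefore a step of no more than the scatter: a number 2 percentage points higher from compound 3 to compound 4 (within the scatter). The estimated value for compound 4 in this assay is 68%, with a range from 55% to 80%.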

Compound 4, a percentage reported as inhibition, in the whole organism at one dose (the size of the read-out at that dose, not a potency): 43%
Compound 4: middle estimate off by 25 percentage points, on the high side, and the stated range ends above it.
By their numbers in this assay, from the lowest: compounds 4 and 2 (each within the scatter of the next); then compounds 3 and 1 (each within the scatter of the next).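

In this assay, diethylcarbamoyl in place of (dimethylcarbamoyl)methyl on a saturated ring carbon gives a number 23 percentage points lower from compound 3 to compound 4 (beyond the scatter) and shows that keeping an amide on this position does not by itself keep the number of compound 3. With the carbonyl on the ring carbon, the group on the amide carbonyl also counts: diethylamino in place of morpholin-4-yl gives a number 30 percentage points lower from compound 1 to compound 4 (beyond the scatter) in the same series, while diethylcarbamoyl in place of propyl gives a number 7 percentage points lower from compound 2 to compound 4 (within the scatter) and leaves these two compounds without an order. No available measurement accounts for these steps.

As far as these compounds go, the step from compound 3 to compound 4 removes the chain carbon and exchanges the two methyl groups for two ethyl groups at once, so the share of each change stays open, and dimethylcarbamoyl directly on this ring carbon would separate them. Also open, from the compounds shown here alone, is how a carboxylic acid or a primary amine on this ring carbon would compare with the amides and the propyl chain.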